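The source may hold more compounds than are shown below. What is called first, only, known or untested is meant among the compounds shown, and "the series" means these compounds.

Measured compounds in a functional assay on A549 cells (Homo sapiens) for antiproliferative activity, read by MTT assay, with a stated time of 72 h; on this read-out higher numbers stand for weaker inhibition and lower numbers for stronger inhibition:
compound 1 `CNC(=O)c1cc(Oc2ccc(NC(=O)c3cc4cccnc4n(-c4ccc(Br)cc4F)c3=O)cc2)ccn1` — 1420 nM
compound 2 `CNC(=O)c1cc(Oc2ccc(NC(=O)c3cc4cccnc4n(-c4ccc(C(F)(F)F)cc4Cl)c3=O)cc2)ccn1` — 2090 nM
compound 3 `CCCNC(=O)c1cc(Oc2ccc(NC(=O)c3cc4cccnc4n(-c4ccc(Br)cc4F)c3=O)cc2)ccn1` — 1310 nM

The three compounds share one core and differ at two places. For the measured compounds named here, the first is the aryl group on the aromatic nitrogen: 2-chloro-4-(trifluoromethyl)phenyl in place of 4-bromo-2-fluorophenyl on an aromatic nitrogen. This change gave a 1.5-fold higher number from compound 1 to compound 2 (0.17 log units; within the scatter). The second is the amide substituent: ethyl in place of hydrogen on a saturated chain carbon bound to an amide-type nitrogen, which gave a 1.1-fold lower number from compound 1 to compound 3 (0.04 log units; within the scatter). Going by the values given here, compound 2 and compound 3 differ at both places at once, so no single step is defined between them; their values in this assay lie within the scatter of each other. Among the compounds with values here, no compound among the three can be called the strongest or weakest, since every step between them is within the scatter.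

Compound 4 `CCCNC(=O)c1cc(Oc2ccc(NC(=O)c3cc4cccnc4n(-c4ccc(C(F)(F)F)cc4Cl)c3=O)cc2)ccn1` has not been measured. Relative to compound 3 it carries 2-chloro-4-(trifluoromethyl)phenyl in place of 4-bromo-2-fluorophenyl on an aromatic nitrogen. The place of this change reads word for word as that of the change from compound 1 to compound 2, so it is the same change on a core that differs only by ethyl in place of hydrogen on a saturated chain carbon bound to an amide-type nitrogen.

The step from compound 3 to compound 4 is expected to be close to the earlier one, a 1.5-fold higher number from compound 3 to compound 4 (0.16 log units; within the scatter), because a 1.5-fold higher number from compound 1 to compound 2 (0.17 log units; within the scatter) was small and because a 1.1-fold lower number from compound 1 to compound 3 (0.04 log units; within the scatter) shows the core change itself did little. Compound 4 is therefore estimated at 1900 nM, expected to fall between 1000 nM and 3600 nM.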

Compound 4, half-maximal inhibitory concentration: 1250 nM
Beside the measured number, compound 4's estimate is 1.5-fold (0.18 log units) above it, and the stated range covers the measured number.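

In this assay, 2-chloro-4-(trifluoromethyl)phenyl in place of 4-bromo-2-fluorophenyl now gives a 1.0-fold lower number from compound 3 to compound 4 (0.02 log units; within the scatter), and this step agrees within the scatter with the same change on the other core: the same change on two cores in this assay, a 1.5-fold higher number (0.17 log units; within the scatter) from compound 1 to compound 2 and a 1.0-fold lower number (0.02 log units; within the scatter) from compound 3 to compound 4, 1.5-fold (0.19 log units) apart, within the scatter of two such steps

The amide change, ethyl in place of hydrogen on the saturated chain carbon, gives a 1.7-fold lower number from compound 2 to compound 4 (0.22 log units; within the scatter), and it too agrees within the scatter with its earlier counterpart: the same change on two cores in this assay, a 1.1-fold lower number (0.04 log units; within the scatter) from compound 1 to compound 3 and a 1.7-fold lower number (0.22 log units; within the scatter) from compound 2 to compound 4, 1.5-fold (0.19 log units) apart, within the scatter of two such steps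

For the compounds shown here, both changes therefore carry from one core to the other in the limited sense that each stays within the scatter on both cores, but with steps this small the agreement says little about transfer, as a real dependence on the core could lie hidden in the scatter and no step of clear size exists here to follow from core to core.

From the compounds shown here alone, it remains open whether any group at these two places moves the number beyond the scatter, for instance a longer chain or a chain ending in an amine on the amide nitrogen, or a nitrile or a methoxy group on the aryl ring. Going by these compounds, whether a step of that size would carry between cores, in this assay or in any other assay, is equally open.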